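The source may report more compounds than this note shows. Statements on the series, on what has been measured and on what is new or still open speak of the compounds shown alone.

Measured so far in an ADME assay on MT2 cells (Homo sapiens) for cytotoxicity; on this read-out lower numbers stand for higher toxicity in this test and higher numbers for lower toxicity in this test:
compound 1, `CC1(C)OC(=O)C2(C(=O)O1)[C@@H](c1ccco1)CC(=O)C[C@H]2c1ccco1`, gives > 111000 nM, a limit
compound 2, `CC1(C)OC(=O)C2(C(=O)O1)[C@@H](c1ccco1)CC(=O)C[C@H]2c1c[nH]c2ccccc12`, gives > 111000 nM, a limit
compound 3, `CC1(C)OC(=O)C2(C(=O)O1)[C@@H](c1ccco1)CC(=O)C[C@H]2c1ccccc1`, gives > 111000 nM, a limit

Each of these three values is a limit of the assay rather than a measured number. Compound 3 stands at the limit of > 111000 nM in this assay, at which 3 of the 3 values shown sit, alongside the other two. The three measured steps give no readable size: a step that the two limits leave unreadable from compound 1 to compound 3, a step that the two limits leave unreadable from compound 1 to compound 2 and a step that the two limits leave unreadable from compound 2 to compound 3.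

Compound 4, `COc1ccc([C@@H]2CC(=O)C[C@H](c3ccco3)C23C(=O)OC(C)(C)OC3=O)cc1`, differs from compound 3 in one place: methoxy in place of hydrogen on an aromatic carbon. For the measured compounds named here, no measured step involves a methoxy group, and the steps that do exist cannot be sized, so there is no basis for expecting a change beyond the scatter in this assay; the expectation is rather that compound 4 stays at the limit. The step from compound 3 to compound 4 is estimated as a number no higher from compound 3 to compound 4 (the limit leaves the size open). Compound 4 is expected to give about 111000 nM, within 50000 nM to 250000 nM, most likely reported again only as a limit.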

Compound 4, half-maximal cytotoxic concentration: > 111000 nM
Compound 4 gave a limit, no number (the forecaster's own chance of this, stated with the estimate: 85%); the middle value sits exactly at the limit.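

The comparisons of compound 4 with compound 1, compound 2 and compound 3 cannot be read, and no step can be sized, because every value is a limit: the limit of > 111000 nM in this assay, at which 4 of the 4 values shown sit.

The compounds shown leave open the concentration at which any of them becomes toxic to these cells, and whether exchanging furan-2-yl, 1H-indol-3-yl, phenyl or 4-methoxyphenyl changes that concentration at all.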